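A few compounds are considered here, and "the series" means these few. Any claim that something is new, unique, unknown or untested is made for them only; others in the source may bear on it.

In an ADME assay on L02 cells (Homo sapiens) for inhibition, read by CCK-8 assay, with a stated time of 48 h (a higher number here means a weaker inhibitor of growth, a lower number a stronger inhibitor of growth), compound 1 (`Cc1ccccc1Nc1nc(Nc2ccc(N3CCN(C)CC3)cn2)ncc1Cl`) gives 5980 nM, compound 2 (`COc1ccccc1CNc1nc(Nc2ccc(N3CCN(C)CC3)cn2)ncc1Cl`) gives 25500 nM and compound 3 (`Cc1ccc(Nc2nc(Nc3ccc(N4CCN(C)CC4)cn3)ncc2Cl)cc1`) gives 13900 nM. Compound 3 thus sits within the scatter of compound 2 and at a higher number than compound 1. Compound 4 (`Cc1cc(C)c(Nc2nc(Nc3ccc(N4CCN(C)CC4)cn3)ncc2Cl)c(C)c1`) differs from compound 3 as follows: 2,4,6-trimethylphenyl in place of 4-methylphenyl on a nitrogen on an aromatic ring. The closest evidence is a 2.3-fold higher number from compound 1 to compound 3 (0.37 log units; beyond the scatter), where 4-methylphenyl replaces 2-methylphenyl. The step of a 4.3-fold higher number from compound 1 to compound 2 (0.63 log units; beyond the scatter) introduces 2-methoxybenzyl and bears on the change less directly. Within the data shown here, no measured compound carries 2,4,6-trimethylphenyl, so only a small move towards a lower number is expected in this assay. The expected step is a 1.7-fold lower number from compound 3 to compound 4 (0.24 log units; within the scatter). Compound 4 is estimated at 8000 nM, with an expected range of 3500 nM to 19000 nM.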

Compound 4, concentration for 50% growth inhibition: 20500 nM
The estimate for compound 4 lay 2.6-fold (0.41 log units) below the measured number; measured number outside the range, above it.
By their numbers in this assay, from the lowest: compound 1; then compounds 3, 4 and 2 (each within the scatter of the next).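

In this assay, 2,4,6-trimethylphenyl in place of 4-methylphenyl on this nitrogen gives no change beyond the scatter, with a 1.5-fold higher number from compound 3 to compound 4 (0.17 log units; within the scatter). The same group also stays level with 2-methoxybenzyl, with a 1.2-fold lower number from compound 2 to compound 4 (0.09 log units; within the scatter), whereas a 3.4-fold higher number from compound 1 to compound 4 (0.54 log units; beyond the scatter) leaves compound 1 apart, the only one of the four with a lower number than all the others beyond the scatter. No measurement shown here explains these differences.

As far as these compounds go, it remains open how a phenyl group carrying an amine or a carboxylic acid would read at this nitrogen, and whether a longer chain in place of the phenyl group would move the number.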